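The source may report more compounds than this note shows. Statements on the series, on what has been measured and on what is new or still open speak of the compounds shown alone.

Compound 1 `CNc1cc(-n2nc(C(C)C)c3c(-n4cnc(-c5cnn(C)c5)c4)ccnc32)ccc1C(N)=O`: 773 nM
Compound 2 `CC(C)c1nn(-c2ccc(C(N)=O)c(N[C@H]3CC[C@H](O)CC3)c2)c2nccc(-n3cnc(-c4ccc(Oc5ccccc5)cc4)c3)c12`: 503 nM
Compound 3 `CC(C)c1nn(-c2ccc(C(N)=O)c(N[C@H]3CC[C@H](O)CC3)c2)c2nccc(-c3ccccc3)c12`: > 10000 nM

All three values come from a functional assay on SK-BR-3 cells (Homo sapiens) for inhibition, read by CellTiter-Glo, with a stated time of 72 h; a lower number here means a stronger inhibitor, a higher number a weaker inhibitor. On these data alone, for compound 3 the result > 10000 nM is only a limit of the assay, not a number, so its true potency is unknown beyond the fact that it sits at the limit of > 10000 nM in this assay, at which 1 of the 3 values shown sits. Compound 1 and compound 2, which carry a larger group bearing a nitrogen-containing ring in the corresponding part of the shared core, give measurable numbers in this assay, and those two numbers lie within the usual scatter of each other.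

The unmeasured compound 4 `CC(C)c1nn(-c2ccc(C(N)=O)c(N[C@H]3CC[C@H](O)CC3)c2)c2nccc(-c3ccc4ccccc4c3)c12` keeps everything of compound 3 except one group: naphthalen-2-yl in place of phenyl on an aromatic carbon. The new group adds a second six-membered carbon ring fused to the first, and nothing that could donate or accept a hydrogen bond.

Because compound 3 stands only at > 10000 nM, any step from it can only be read as a possible gain, and the step of an at least 1.2-fold lower number from compound 3 to compound 4 (0.09 log units; that floor lies within the scatter) is expected to be modest, perhaps just past the scatter, with a real chance that compound 4 also stays at the limit. Compound 4 is therefore estimated at 8000 nM, with a plausible range from 2500 nM to 30000 nM.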

Compound 4, half-maximal inhibitory concentration: > 10000 nM
Compound 4: only a limit was reported; the forecaster's own chance of this, stated with the estimate: 45%; middle value at least 1.2-fold (0.09 log units) from the limit.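

In this assay compound 4 gives > 10000 nM, which is a limit and not a number. Compound 3 also stands at a limit, so no step between compound 3 and compound 4 can be read: the limit of > 10000 nM in this assay, at which 2 of the 4 values shown sit.

The compounds shown leave open whether naphthalen-2-yl in place of phenyl changes potency at all.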